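The source may report more compounds than this note shows. Statements on the series, on what has been measured and on what is new or still open speak of the compounds shown alone.

Measured so far:
Compound 1 `Cn1nnnc1SCC(=O)N/N=c1/scc(-c2ccccc2)n1-c1ccccc1` gives 173 ug/mL in an ADME assay on NIH3T3 cells (Mus musculus) for cytotoxicity, read by MTT assay, with a stated time of 24 h; a higher number here means a weaker inhibitor, a lower number a stronger inhibitor.
Compound 3 `Cn1nnnc1SCC(=O)N/N=c1/scc(-c2ccc(C#N)cc2)n1-c1ccccc1` gives 213 ug/mL in this assay.
Compound 2 `O=C(CSc1ncccn1)N/N=c1/scc(-c2ccc(F)cc2)n1-c1ccccc1` reaches only a limit of the assay, > 500 ug/mL in this assay.

Compound 3 carries the higher of the two numbers, though a 1.2-fold higher number from compound 1 to compound 3 (0.09 log units; within the scatter) stays within the scatter. The third value is a limit (the limit of > 500 ug/mL in this assay, at which 1 of the 3 values shown sits).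

Compound 4 `Cn1nnnc1SCC(=O)N/N=c1/scc(-c2ccc(F)cc2)n1-c1ccccc1` differs from compound 3 in one place: fluoro in place of cyano on an aromatic carbon. Within the data shown here, the only measured step, a 1.2-fold higher number from compound 1 to compound 3 (0.09 log units; within the scatter), concerns cyano in place of hydrogen and was flat; no measured step covers fluoro in place of cyano, and compound 2, which carries fluoro, offers only a limit. The step is therefore expected to stay within the scatter, a 1.1-fold higher number from compound 3 to compound 4 (0.03 log units; within the scatter). Compound 4 is estimated at 230 ug/mL, between 110 ug/mL and 480 ug/mL.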

Compound 4, half-maximal inhibitory concentration: 113 ug/mL
The estimate for compound 4 lay 2.0-fold (0.31 log units) above the measured number; the range from low to high includes it.
By their numbers in this assay, from the lowest: compounds 4, 1 and 3 (each within the scatter of the next). At a limit, above all of these: compound 2.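

At the aromatic carbon para to a large group, fluoro, cyano and hydrogen show no separation in this assay (with a 1.9-fold lower number from compound 3 to compound 4 (0.28 log units; within the scatter) and a 1.5-fold lower number from compound 1 to compound 4 (0.18 log units; within the scatter)). Compound 2 gives only a limit of the assay (> 500 ug/mL). Among these compounds, the only change beyond the scatter therefore sits on the sulfur, with 1-methyl-1H-tetrazol-5-yl in place of pyrimidin-2-yl (an at least 4.4-fold lower number from compound 2 to compound 4 (0.64 log units; beyond the scatter)).

Going by these compounds, this sulfur change rests on a single pair, so its size remains open. Also open, on these data alone, is how an amine or a carboxylic acid on that aromatic carbon would read.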